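Replacing the Hydroxy Group of Compound 3 with Chloro

A few compounds are considered here, and "the series" means these few. Any claim that something is new, unique, unknown or untested is made for them only; others in the source may bear on it.

Compound 3 `Cc1cc(NC(=O)Nc2ccc(O)cc2)c2ccccc2n1` stands lowest of the three measured compounds in an ADME assay for permeability, using PAMPA, at pH 7.4 (on this read-out lower numbers stand for lower permeability and higher numbers for higher permeability), where compound 3 gives 3 10^-6 cm/s. Compound 1 `Cc1cc(NC(=O)Nc2ncccc2C)c2ccccc2n1` gives 369 10^-6 cm/s and compound 2 `Cc1cc(NC(=O)Nc2ccc(N)cc2)c2ccccc2n1` gives 530 10^-6 cm/s. The steps of a 120-fold lower number from compound 1 to compound 3 (2.09 log units; beyond the scatter) and a 180-fold lower number from compound 2 to compound 3 (2.25 log units; beyond the scatter) are both large, whereas a 1.4-fold higher number from compound 1 to compound 2 (0.16 log units; within the scatter) is not. Compound 4 `Cc1cc(NC(=O)Nc2ccc(Cl)cc2)c2ccccc2n1` differs from compound 3 by chloro in place of hydroxy on an aromatic carbon. Of the measured steps, a 180-fold lower number from compound 2 to compound 3 (2.25 log units; beyond the scatter) bears most directly on this change, as it alone exchanges a single group on the same aromatic carbon, and compound 4 carries neither amino nor hydroxy there. A large rise is therefore expected, a 170-fold higher number from compound 3 to compound 4 (2.22 log units; beyond the scatter), returning compound 4 to the region of compound 1 and compound 2. Compound 4 is estimated to give 500 10^-6 cm/s, within 150 10^-6 cm/s to 1500 10^-6 cm/s.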

Compound 4, apparent permeability: 537 10^-6 cm/s
Beside the measured number, compound 4's estimate is 1.1-fold (0.03 log units) below it, and the stated range covers the measured number.
By their numbers in this assay, from the lowest: compound 3; then compounds 1, 2 and 4 (each within the scatter of the next).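

Among hydroxy, amino and chloro on this aromatic carbon, only hydroxy stands apart in this assay, with a 180-fold higher number from compound 3 to compound 4 (2.25 log units; beyond the scatter) when chloro takes its place. Chloro and amino are not distinguished here, at a 1.0-fold higher number from compound 2 to compound 4 (0.01 log units; within the scatter), and the larger exchange of 3-methylpyridin-2-yl for 4-chlorophenyl, at a 1.5-fold higher number from compound 1 to compound 4 (0.16 log units; within the scatter), also stays within the scatter. No measurement at hand accounts for the hydroxy compound's separate position. On these data alone, it remains open whether methoxy, which keeps the oxygen but not its hydrogen, or a carboxylic acid on this carbon would fall with compound 3 or with compound 4.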